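This account rests on a few compounds, and the source may have more. Where it says the series, first, only, none or still open, it means among the compounds named here.

Measured compounds:
- compound 1 `C=C(C)C(=O)c1ccc(OCc2nc(-c3ccc(C(F)(F)F)cc3)no2)cc1Br` — 1300 nM
- compound 2 `C=C(C)C(=O)c1ccc(OCc2nc(-c3ccccc3)no2)cc1C` — 1970 nM
- compound 3 `C=C(C)C(=O)c1ccc(OCc2nc(-c3ccc([N+](=O)[O-])cc3)no2)c(C)c1C` — 2300 nM

Of the compounds shown here, three built on the shared core have been tested in an assay on HL-60 cells for inhibition of glutathione S-transferase P (Homo sapiens); a higher number here means a weaker inhibitor, a lower number a stronger inhibitor. Compound 1 gives 1300 nM, the lowest of the three numbers. Its nearest neighbour is compound 2, and the gap between the two lies within the scatter of repeated measurements. The furthest is compound 3, and that gap too lies within the scatter. So the three numbers cannot be separated from one another with any confidence, and compound 1 is not singled out as a stronger inhibitor than the other two.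

The next compound is compound 4 `C=C(C)C(=O)c1ccc(OCc2nc(-c3ccc(C(F)(F)F)cc3)no2)cc1Cl`, which has not yet been tested in this assay. It differs from compound 1 in one place: chloro in place of bromo on an aromatic carbon. The rest of the molecule, including the trifluoromethyl-bearing aryl group and the (1-methylethenyl)carbonyl group, is unchanged.

Among the compounds with values here, no measured pair in this set shows what this exchange does. Within the data shown here, with nothing to go on beyond the single value for compound 1, the expectation is that the step from compound 1 to compound 4 is small and in no clear direction, a 1.2-fold higher number from compound 1 to compound 4 (0.06 log units; within the scatter), which would be within the scatter. Compound 4 is therefore estimated at 1500 nM, with a range from 600 nM to 4000 nM.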

Compound 4, half-maximal inhibitory concentration: 700 nM
Compound 4: middle estimate off by 2.1-fold (0.33 log units), on the high side; the range from low to high includes it.
By their numbers in this assay, from the lowest: compounds 4, 1, 2 and 3 (each within the scatter of the next, the first and the last beyond it).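

Within the data shown here, at the position ortho to the (1-methylethenyl)carbonyl group, the exchange of bromo for chloro gives the first step in this set that can be read between two compounds differing in one place: in this assay there is a 1.9-fold lower number from compound 1 to compound 4 (0.27 log units; within the scatter), with the trifluoromethyl-bearing aryl group and the rest of the molecule held fixed. Among these compounds, this step does not separate the two compounds, so in this single pair chloro and bromo at this position cannot be told apart, and inhibition in the low micromolar range of the earlier compounds is kept with either halogen. No measurement in hand bears on what lies behind the size of this step.

The compounds shown leave open whether a group other than these two halogens at this position, such as fluoro, methoxy or an amine, would give a number beyond the scatter. They also leave open whether chloro and bromo would remain indistinguishable on a different aryl group, for example one carrying a nitro group in place of the trifluoromethyl.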